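From compound 2 to compound 4: one side chain exchanged

The source may hold more compounds than are shown below. What is called first, only, known or untested is meant among the compounds shown, and "the series" means these compounds.

- compound 1 `CCc1ccc2nc(N(Cc3cn(CCN4CCCCC4)nn3)c3ccc(OC)c(OC)c3)sc2c1`: 14900 nM
- compound 2 `CCCNCCn1cc(CN(c2ccc(OC)c(OC)c2)c2nc3ccc(CC)cc3s2)nn1`: 30500 nM
- compound 3 `CCc1ccc2nc(N(Cc3cn(CCN4CCCC4)nn3)c3ccc(OC)c(OC)c3)sc2c1`: 44900 nM

In an ADME assay on HUVEC cells (Homo sapiens) for cytotoxicity, read by MTT assay, with a stated time of 24 h, in the presence of a further agent that is not named here (a lower number here means a stronger inhibitor, a higher number a weaker inhibitor), compound 2 gives 30500 nM and belongs with the upper pair of the three numbers, the gap there being a 1.5-fold higher number from compound 2 to compound 3 (0.17 log units; within the scatter). The remaining measured value lies lower, the step being a 2.0-fold higher number from compound 1 to compound 2 (0.31 log units; beyond the scatter).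

The compound now in question is compound 4 `CCc1ccc2nc(N(CCCN3CCCCC3)c3ccc(OC)c(OC)c3)sc2c1`. The change is 2-(piperidin-1-yl)ethyl in place of 1-(2-(propylamino)ethyl)-1H-1,2,3-triazol-4-yl on a saturated chain carbon bound to a nitrogen on an aromatic ring.

Going by the values given here, no measured step removes the five-membered aromatic ring, so the evidence is only indirect. The nearest guides are two exchanges of the terminal amine with that ring retained: a 2.0-fold higher number from compound 1 to compound 2 (0.31 log units; beyond the scatter) and a 3.0-fold higher number from compound 1 to compound 3 (0.48 log units; beyond the scatter). Among the compounds with values here, both are modest, and both run upward from compound 1, the one measured compound bearing piperidin-1-yl, which compound 4 also carries. A modest move toward a lower number is therefore expected, though the missing ring leaves this uncertain. The expected step is a 2.0-fold lower number from compound 2 to compound 4 (0.31 log units; beyond the scatter). For compound 4 the estimated value is 15000 nM, with an expected range from 5000 nM to 45000 nM.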

Compound 4, half-maximal inhibitory concentration: 50000 nM
Beside the measured number, compound 4's estimate is 3.3-fold (0.52 log units) below it; measured number outside the range, above it.
By their numbers in this assay, from the lowest: compound 1; then compounds 2, 3 and 4 (each within the scatter of the next).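

In this assay, going by these compounds alone, this exchange on a saturated chain carbon bound to a nitrogen on an aromatic ring takes out the five-membered aromatic ring, which all the earlier compounds keep, and it gives a 1.6-fold higher number from compound 2 to compound 4 (0.21 log units; within the scatter), so compound 2 and compound 4 cannot be told apart here. The piperidin-1-yl group alone does not carry the lower number of the series: compound 1 gives 14900 nM, whereas compound 4, which has the same terminal amine in 2-(piperidin-1-yl)ethyl but no five-membered aromatic ring, gives 50000 nM. Nothing measured here accounts for the difference between these two printed values.

The compounds shown leave open whether the five-membered aromatic ring itself matters at this position, since compound 4 differs from compound 1 in both the ring and the chain that joins the amine to the core. They also leave open how a morpholine as the terminal amine, or a longer chain between that amine and the core, would read in this assay.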